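Hexyl for cyclohexyl on the carbamate nitrogen

The source may report more compounds than this note shows. Statements on the series, on what has been measured and on what is new or still open speak of the compounds shown alone.

Two measured members of the series stand on record. Compound 1 `CCCCCCNC(=O)Oc1cccc(-c2cc(C(=O)OCC)nn2-c2ccccc2)c1` gives 88 nM in an assay on isolated protein for inhibition of Fatty-acid amide hydrolase 1 (Homo sapiens), read by fluorescence, with a stated time of 30 min; on this read-out lower numbers stand for stronger inhibition and higher numbers for weaker inhibition. Compound 2 `CCCOC(=O)c1cc(-c2cccc(OC(=O)NC3CCCCC3)c2)n(-c2ccccc2)n1` gives 27 nM in this assay, the lowest of the two numbers; compound 1 is its nearest neighbour at a higher number, a gap beyond the usual scatter. The two differ from each other in more than one place, so no single change is assigned to that gap.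

Compound 3 `CCCCCCNC(=O)Oc1cccc(-c2cc(C(=O)OCCC)nn2-c2ccccc2)c1` is not yet measured. It arises from compound 2 by hexyl in place of cyclohexyl on an amide-type nitrogen, so that it carries the same hexyl group on the amide-type nitrogen as compound 1 while keeping the rest of compound 2. Because compound 1 with the hexylcarbamoyl group gives 88 nM whereas compound 2 with the cyclohexylcarbamoyl group gives 27 nM, a moderate step toward a higher number is expected for compound 3 from compound 2, near the edge of the scatter. The step of a 2.2-fold higher number from compound 2 to compound 3 (0.35 log units; beyond the scatter) is the estimated size. Compound 3 is expected to give about 60 nM in this assay, with a range from 25 nM to 150 nM.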

Compound 3, half-maximal inhibitory concentration: 101 nM
Compound 3: the middle estimate sits 1.7-fold (0.23 log units) below what was measured; measured number inside the range.
By their numbers in this assay, from the lowest: compound 2; then compounds 1 and 3 (each within the scatter of the next).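

The gap between compound 1 and compound 2 can now be divided, which the two alone did not allow. In this assay, hexyl in place of cyclohexyl on an amide-type nitrogen gives a 3.7-fold higher number from compound 2 to compound 3 (0.57 log units; beyond the scatter) and so accounts for a step beyond the scatter, even though the two groups match in heavy atoms and carbon count and differ in that cyclohexyl holds them in a six-membered ring while hexyl has no ring. Methyl in place of hydrogen on a saturated chain carbon, two bonds along the chain from an oxygen next to a carbonyl group, gives a 1.1-fold higher number from compound 1 to compound 3 (0.06 log units; within the scatter) and stays within the scatter with hexyl on the nitrogen, so the measured difference sits with the change at the nitrogen. No measurement in hand explains why the ring and the open chain differ in this assay.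

For the compounds shown here, whether the same methyl change is equally silent with cyclohexyl on the nitrogen remains open, as no pair tests it. Going by these compounds, how far the preference for cyclohexyl extends also remains open, for instance to cyclopentyl, cycloheptyl or a longer chain on the same nitrogen.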